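Swapping a chloropropyl chain for a methoxyphenyl ring

The compounds below may be only part of what the source reports. "The series", "measured", "known", "first", "only" and "open" are said of these compounds alone.

Of the compounds shown here, three built on one shared core have been tested in a functional assay on A549 cells (Homo sapiens) for antiproliferative activity, read by MTT assay, with a stated time of 72 h; on this read-out lower numbers stand for stronger inhibition and higher numbers for weaker inhibition. Compound 1 `CCCCCc1ccc(-c2cn(C[C@H](O)[C@H]3OC(=O)C(OCc4ccccc4)=C3OCc3ccccc3)nn2)cc1` carries a 4-pentylphenyl group and gives 6220 nM. Compound 2 `CC(C)(C)c1cn(C[C@H](O)[C@H]2OC(=O)C(OCc3ccccc3)=C2OCc2ccccc2)nn1` carries a tert-butyl group at the same spot and gives 34000 nM. Compound 3 `O=C1O[C@H]([C@@H](O)Cn2cc(CCCCl)nn2)C(OCc2ccccc2)=C1OCc1ccccc1` carries a 3-chloropropyl group there and gives 29000 nM. Compound 3 and compound 2 lie within the scatter of each other, as the step of a 1.2-fold lower number from compound 2 to compound 3 (0.07 log units; within the scatter) shows, whereas the steps of a 4.7-fold higher number from compound 1 to compound 3 (0.67 log units; beyond the scatter) and a 5.5-fold higher number from compound 1 to compound 2 (0.74 log units; beyond the scatter) set compound 1 apart with the lowest number of the three. Compound 4 `COc1ccc(-c2cn(C[C@H](O)[C@H]3OC(=O)C(OCc4ccccc4)=C3OCc3ccccc3)nn2)cc1` is compound 3 with one group exchanged: 4-methoxyphenyl in place of 3-chloropropyl on an aromatic carbon. The step of a 4.7-fold higher number from compound 1 to compound 3 (0.67 log units; beyond the scatter) is the closest guide, as it too sets a 4-pentylphenyl group against the 3-chloropropyl chain; read in the opposite direction, towards a ring-bearing group, it points to a modest drop in the number. Compound 4 is therefore expected to give about 10000 nM, with a likely range from 3000 nM to 30000 nM. The expected step is a 2.9-fold lower number from compound 3 to compound 4 (0.46 log units; beyond the scatter).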

Compound 4, half-maximal inhibitory concentration: 28300 nM
Compound 4: middle estimate off by 2.8-fold (0.45 log units), on the low side; the range from low to high includes it.
By their numbers in this assay, from the lowest: compound 1; then compounds 4, 3 and 2 (each within the scatter of the next).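

The ring alone does not bring the number down at this position in this assay. The 4-methoxyphenyl group of compound 4 stays within the scatter of both the open chain and the compact tert-butyl group: a 1.0-fold lower number from compound 3 to compound 4 (0.01 log units; within the scatter) and a 1.2-fold lower number from compound 2 to compound 4 (0.08 log units; within the scatter). The group carried on the ring matters instead, as methoxy and pentyl are the only difference in a 4.5-fold higher number from compound 1 to compound 4 (0.66 log units; beyond the scatter), and no measurement at hand explains this gap.

Going by these compounds, whether the pentyl chain owes its lower number to its length remains open, and a 4-butylphenyl or 4-heptylphenyl group would test this. A plain phenyl ring or a 4-aminophenyl group would also show how far the outcome depends on what sits on the ring.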